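The source may report more compounds than this note shows. Statements on the series, on what has been measured and on what is new or still open speak of the compounds shown alone.

The series shares the core of compound 1 `O=c1ccoc2cc(OCc3cn(Cc4cccc(Br)c4)nn3)ccc12`, varied only at the saturated chain carbon bound to an aromatic nitrogen. In a functional assay on A549 cells (Homo sapiens) for cytotoxicity, read by MTT assay, with a stated time of 48 h (a lower number here means a stronger inhibitor, a higher number a weaker inhibitor), compound 1 gives only a limit, > 100000 nM. Compound 2 `CC(C)(C)c1ccc(Cn2cc(COc3ccc4c(=O)ccoc4c3)nn2)cc1` likewise gives only a limit, > 100000 nM, in this assay. Compound 3 `O=c1ccoc2cc(OCc3cn(Cc4ccccc4Cl)nn3)ccc12` also gives only a limit, > 100000 nM, in this assay. Every value in the set thus sits at a limit, (the limit of > 100000 nM in this assay, at which 3 of the 3 values shown sit), and compound 1 cannot be placed against the other two beyond that. Going by the values given here, the single step joining measured compounds, a step that the two limits leave unreadable from compound 1 to compound 3, is left unreadable by the two limits. Compound 4 `O=c1ccoc2cc(OCc3cn(Cc4ccc(Br)cc4)nn3)ccc12` differs from compound 1 by 4-bromophenyl in place of 3-bromophenyl on a saturated chain carbon bound to an aromatic nitrogen. Among the compounds with values here, only the step from compound 1 to compound 3 bears on this kind of change, and its size is not readable, so no step of readable size is expected in this assay in either direction, and a further limit is the likeliest outcome. Compound 4 is estimated at 150000 nM, with a range from 50000 nM to 500000 nM. The expected step is a step that the limit leaves unreadable from compound 1 to compound 4.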

Compound 4, half-maximal inhibitory concentration: > 100000 nM
Compound 4 ended at the assay's limit; the forecaster's own chance of this, stated with the estimate: 85%; the middle value is on the limit's open side.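

The steps joining compound 4 to compound 1, compound 2 and compound 3 cannot be read in this assay, as each value in the set is a limit: the limit of > 100000 nM in this assay, at which 4 of the 4 values shown sit.

The compounds shown leave open how far these four lie apart, and whether any change at this place on the shared core gives a readable value.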